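The source may hold more compounds than are shown below. What is called first, only, known or untested is meant among the compounds shown, and "the series" means these compounds.

Compound 1 (`CCOC(=O)C(=O)CC(=O)/C=C/c1cn(CCC(C)C)c2ccccc12`) carries an ethoxycarbonyl group, and the question here is what happens when that group becomes a carboxy group. In an ADME assay on HeLa cells (Homo sapiens) for inhibition, read by MTT assay, with a stated time of 48 h (a lower number here means a stronger inhibitor, a higher number a weaker inhibitor), compound 1 has no single number: its entry reads "not determined" (no result reported) and nothing more. Compound 2 (`CCOC(=O)C(=O)CC(=O)/C=C/c1cn(-c2ccccc2)c2ccccc12`) also carries the ethoxycarbonyl group and has the same kind of entry, "not determined" (no result reported) in this case. Compound 3 (`CCOC(=O)C(=O)CC(=O)/C=C/c1cn(Cc2ccccc2)c2ccccc12`) gives > 40000 nM in this assay and this is a limit of the assay, not a number.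

Compound 4 (`CC(C)CCn1cc(/C=C/C(=O)CC(=O)C(=O)O)c2ccccc21`) has not yet been measured. The change is a single one: hydrogen in place of ethyl on an oxygen next to a carbonyl group and the result is hydrogen in place of ethyl on an oxygen next to a carbonyl group, so ethoxycarbonyl becomes carboxy. Among the compounds with values here, no measured pair shows what this swap does in this assay and compound 1 offers no number to start from. Within the data shown here, the limit for compound 3 at > 40000 nM is the only nearby reading, so the expected step is none beyond the usual scatter, with inhibition staying weak. For compound 4 the estimated value is 35000 nM with an expected range from 10000 nM to 80000 nM and the assay may well report only a limit again.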

Compound 4, half-maximal inhibitory concentration: > 80000 nM
Compound 4 gave a limit, no number (the forecaster's own chance of this, stated with the estimate: 60%); at least 2.2-fold (0.35 log units) between middle value and limit.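

Within the data shown here, compound 1 has no single number in this assay, so no step from it to compound 4 can be read. Compound 4 gives a limit and not a number: the limit of > 80000 nM in this assay, at which 1 of the 4 values shown sits.

The compounds shown leave open what changing ethoxycarbonyl to carboxy does to inhibition, and whether any of them reaches a measurable value in this assay.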